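Extending an alkoxy chain on a pyrimidinone ester series

The compounds below may be only part of what the source reports. "The series", "measured", "known", "first", "only" and "open" are said of these compounds alone.

Measured compounds:
compound 1, `CCOC(=O)c1cnc(-c2ccccc2OCC)[nH]c1=O`, 2 mg/kg
compound 2, `CCCOc1ccccc1-c1ncc(C(=O)OCC)c(=O)[nH]1`, 5 mg/kg
compound 3, `CCOC(=O)c1cnc(-c2cc(OC)ccc2OCC)[nH]c1=O`, 0.3 mg/kg

The three measured compounds were tested in a functional assay on the whole organism (strain Sprague-Dawley) for inhibition, with Rattus norvegicus as the target, with a stated time of 10 min; a higher number here means that more compound is needed for the effect, a lower number that less compound is needed. Compound 1 gives 2 mg/kg. Compound 2 differs from compound 1 by methyl in place of hydrogen on a saturated chain carbon, two bonds along the chain from an oxygen on an aromatic ring, and this change gives a 2.5-fold higher number from compound 1 to compound 2 (0.40 log units; beyond the scatter). Compound 3 differs from compound 1 by methoxy in place of hydrogen on an aromatic carbon, and here the step is a 6.7-fold lower number from compound 1 to compound 3 (0.82 log units; beyond the scatter), so compound 3 has the lowest number of the three in this assay.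

Compound 4, `CCCOc1ccc(OC)cc1-c1ncc(C(=O)OCC)c(=O)[nH]1`, has not yet been measured. It differs from compound 3 by methyl in place of hydrogen on a saturated chain carbon, two bonds along the chain from an oxygen on an aromatic ring. This is the same change that was made from compound 1 to compound 2, at the same place, and the two starting compounds differ from each other by methoxy in place of hydrogen on an aromatic carbon. Within the data shown here, the only measured step for this change is a 2.5-fold higher number from compound 1 to compound 2 (0.40 log units; beyond the scatter), so the expectation for compound 4 in this assay rests on that single step applied to compound 3, which gives 0.3 mg/kg. Because of a 2.5-fold higher number from compound 1 to compound 2 (0.40 log units; beyond the scatter), a step of a 2.3-fold higher number from compound 3 to compound 4 (0.37 log units; beyond the scatter) is expected from compound 3 to compound 4. On this basis compound 4 is estimated to give 0.7 mg/kg in this assay, with a likely range from 0.3 mg/kg to 1.8 mg/kg. Whether the extra methoxy group of compound 3 changes how this step plays out cannot be judged from a single prior example.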

Compound 4, dose for 50% inhibition: 0.7 mg/kg
For compound 4 middle estimate and measured number coincide at the digits printed; the range from low to high includes it.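

In this assay, extending ethoxy to propoxy on the methoxy-bearing core gives a 2.3-fold higher number from compound 3 to compound 4 (0.37 log units; beyond the scatter), and this step closely matches the one seen on the core without methoxy: the same change on two cores in this assay, a 2.5-fold higher number (0.40 log units; beyond the scatter) from compound 1 to compound 2 and a 2.3-fold higher number (0.37 log units; beyond the scatter) from compound 3 to compound 4, 1.1-fold (0.03 log units) apart, within the scatter of two such steps. Read the other way around the same four compounds, adding the methoxy group to the propoxy compound gives a 7.1-fold lower number from compound 2 to compound 4 (0.85 log units; beyond the scatter), and this step also closely matches its earlier counterpart: the same change on two cores in this assay, a 6.7-fold lower number (0.82 log units; beyond the scatter) from compound 1 to compound 3 and a 7.1-fold lower number (0.85 log units; beyond the scatter) from compound 2 to compound 4, 1.1-fold (0.03 log units) apart, within the scatter of two such steps. Within these four compounds, each change therefore keeps its size whichever of the two cores carries it, so the two changes simply add up, but this rests on only two pairs per change in one whole-animal assay and shows neither why the numbers move nor that other changes or cores would behave the same way.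

The compounds shown leave open whether the trend continues with a longer chain such as butoxy, or how a branched chain such as isopropoxy would fit the same pattern. They also leave open whether a different group in place of methoxy, such as chlorine or an amine, or a carboxylic acid in place of the ethyl ester, would carry over between cores as predictably.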